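Thiophen-3-yl in place of 1H-pyrrol-1-yl on the shared core

The compounds below may be only part of what the source reports. "The series", "measured", "known", "first", "only" and "open" are said of these compounds alone.

For the measured compounds named here, in a functional assay on MCF7 cells (Homo sapiens) for antiproliferative activity, read by sulforhodamine B assay (on this read-out lower numbers stand for stronger inhibition and higher numbers for weaker inhibition), compound 1 (`CN1CCN(c2ccc(N/C=C3\C(=O)NC(=O)c4ccc(-n5cccc5)cc43)cc2)CC1`) gives 2300 nM as the higher of the two numbers so far, and compound 2 (`O=C1NC(=O)c2ccc(I)cc2/C1=C/Nc1ccc(CN2CCCCC2)cc1`) gives 1000 nM which lies lower by more than the usual scatter. Compound 3 (`CN1CCN(c2ccc(N/C=C3\C(=O)NC(=O)c4ccc(-c5ccsc5)cc43)cc2)CC1`) carries thiophen-3-yl in place of 1H-pyrrol-1-yl on an aromatic carbon. Going by the values given here, no measured step bears on this change, so in this assay only a small shift toward stronger inhibition, probably none beyond the scatter, is expected (a 1.5-fold lower number from compound 1 to compound 3 (0.19 log units; within the scatter)). For compound 3 the estimated value is 1500 nM with an expected range from 600 nM to 3500 nM in this measurement.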

Compound 3, half-maximal inhibitory concentration: 2300 nM
The estimate for compound 3 lay 1.5-fold (0.19 log units) below the measured number; measured number inside the range.
By their numbers in this assay, from the lowest: compound 2; then compounds 1 and 3 (each within the scatter of the next).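

In this assay, for the compounds shown here, thiophen-3-yl in place of 1H-pyrrol-1-yl on this aromatic carbon gives no change at the digits printed from compound 1 to compound 3 (within the scatter) and so provides the first reading at this position: these two five-membered aromatic rings, each with 1 hetero atom, cannot be told apart here. Nothing available explains this outcome.

Still open, on these data alone, is how a phenyl ring, a primary amine or a carboxylic acid on the same aromatic carbon would compare with these two groups. Also open, as far as these compounds go, is whether this swap would give the same result with other groups elsewhere on the shared core.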